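The compounds below may be only part of what the source reports. "The series", "measured", "known", "first", "only" and "open" are said of these compounds alone.

Measured so far:
compound 1 (`COc1ccc(CN(C(=O)CSC2=CN=NC2C)c2cc(OC)c(OC)c(OC)c2)cc1`) gives 45000 nM
compound 2 (`COc1ccc(CN(C(=O)CCSc2nc3ccccc3o2)c2cc(OC)c(OC)c(OC)c2)cc1`) gives 20200 nM
compound 3 (`COc1ccc(CN(C(=O)CCCSc2nc3ccccc3o2)c2cc(OC)c(OC)c(OC)c2)cc1`) gives 32700 nM

All three numbers come from a functional assay on PC-3 cells (Homo sapiens) for antiproliferative activity, read by MTT assay, with a stated time of 48 h; on this read-out higher numbers stand for weaker inhibition and lower numbers for stronger inhibition. Compound 3 cannot be told apart from either of the other two (a 1.4-fold lower number from compound 1 to compound 3 (0.14 log units; within the scatter) and a 1.6-fold higher number from compound 2 to compound 3 (0.21 log units; within the scatter)), since both steps lie within the scatter.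

Compound 4 (`COc1ccc(CN(C(=O)CCCCSc2nc3ccccc3o2)c2cc(OC)c(OC)c(OC)c2)cc1`) differs from compound 3 in one place (((1,3-benzoxazol-2-yl)sulfanyl)methyl in place of (1,3-benzoxazol-2-yl)sulfanyl on a saturated chain carbon, three bonds along the chain from a carbonyl carbon). It has ((1,3-benzoxazol-2-yl)sulfanyl)methyl in place of (1,3-benzoxazol-2-yl)sulfanyl on a saturated chain carbon, three bonds along the chain from a carbonyl carbon.

The closest guide is the same swap made two bonds along the chain from a carbonyl carbon (a 1.6-fold higher number from compound 2 to compound 3 (0.21 log units; within the scatter)), which stayed within the scatter. The exchange of the whole group on the chain (a 2.2-fold lower number from compound 1 to compound 2 (0.35 log units; beyond the scatter)) was modest and says less about this change. No step beyond the scatter is therefore expected in this assay, and the estimated step is small (a 1.1-fold lower number from compound 3 to compound 4 (0.04 log units; within the scatter)). Compound 4 is estimated at 30000 nM (expected range 13000 nM to 70000 nM).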

Compound 4, half-maximal inhibitory concentration: 45600 nM
Beside the measured number, compound 4's estimate is 1.5-fold (0.18 log units) below it; measured number inside the range.
By their numbers in this assay, from the lowest: compounds 2, 3, 1 and 4 (each within the scatter of the next, the first and the last beyond it).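

In this assay, the swap to ((1,3-benzoxazol-2-yl)sulfanyl)methyl three bonds along the chain from a carbonyl carbon stays within the scatter (a 1.4-fold higher number from compound 3 to compound 4 (0.14 log units; within the scatter)), so this single lengthening cannot be told apart from no change. Comparing compound 2 and compound 4 gives a different picture: with 2-((1,3-benzoxazol-2-yl)sulfanyl)ethyl in place of (1,3-benzoxazol-2-yl)sulfanyl, the chain change gives its first step beyond the scatter (a 2.3-fold higher number from compound 2 to compound 4 (0.35 log units; beyond the scatter)), though only a modest one. Lengthening the chain therefore weakens inhibition measurably across this wider span, while neither single step can be read on its own.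

The data offer no explanation for this result. As far as these compounds go, it also remains open whether a still longer chain, or an amine or a carboxylic acid in place of the (1,3-benzoxazol-2-yl)sulfanyl group, would shift the number further.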